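Methoxyphenyl in place of fluorophenyl: cytotoxicity estimate

The compounds below may be only part of what the source reports. "The series", "measured", "known", "first", "only" and "open" are said of these compounds alone.

Measured compounds:
Compound 1 `Cc1cc(-c2cccc(F)c2)c2ncc(CSCCc3ccccc3)n2c1` gives 35 ug/mL in an ADME assay on HEL cells (Homo sapiens) for cytotoxicity, with a stated time of 3 days; a lower number here means that less compound is tolerated, a higher number that more compound is tolerated.
Compound 2 `COc1ccc(-c2cc(C)c3ncc(CSCCc4ccccc4)n3c2)cc1` gives 25.8 ug/mL in this assay.
Compound 3 `Cc1cc(-c2cccc([N+](=O)[O-])c2)cn2c(CSCCc3ccccc3)cnc12` gives 43 ug/mL in this assay.

Compound 1 stands second highest among the measured numbers; its nearest neighbour is compound 3 and its furthest is compound 2, and both gaps are within the scatter. Compound 4 `COc1ccc(-c2cc(C)cn3c(CSCCc4ccccc4)cnc23)cc1` keeps the core of compound 1 and differs from it in one place: 4-methoxyphenyl in place of 3-fluorophenyl on an aromatic carbon.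

For the measured compounds named here, the only measured step that bears on this change is the aryl swap in a 1.7-fold higher number from compound 2 to compound 3 (0.22 log units; within the scatter), which lies within the scatter, though it exchanges a different pair of groups and sits on the core of compound 2 rather than that of compound 1. Compounds 2 and 4 both carry 4-methoxyphenyl but on differently arranged cores, so their values are not a direct comparison. All measured values lie within the scatter of one another, so no step beyond the scatter is expected for a 1.1-fold lower number from compound 1 to compound 4 (0.04 log units; within the scatter). Compound 4 is therefore estimated at 32 ug/mL, within 16 ug/mL to 64 ug/mL.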

Compound 4, half-maximal cytotoxic concentration: 19.6 ug/mL
Estimate against measurement, compound 4: 1.6-fold (0.21 log units) above; low and high end bracket the measured number.
By their numbers in this assay, from the lowest: compounds 4, 2, 1 and 3 (each within the scatter of the next, the first and the last beyond it).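

In this assay, this exchange can now be read directly at this position on the core of compound 1, with a 1.8-fold lower number from compound 1 to compound 4 (0.25 log units; within the scatter). For the compounds shown here, until now, the only aryl exchange available was one between a different pair of groups on another core; this one shows that 4-methoxyphenyl can stand in place of 3-fluorophenyl on this aromatic carbon, ortho to a fused ring, without a step beyond the scatter. Nothing at hand accounts for the size of this step.

The change moves the substituent around the phenyl ring and alters its identity at once, so 3-methoxyphenyl or 4-fluorophenyl would be needed to separate the two. On these data alone, it also remains open whether an amine or a carboxylic acid on this phenyl ring would give a step beyond the scatter.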